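A few compounds are considered here, and "the series" means these few. Any claim that something is new, unique, unknown or untested is made for them only; others in the source may bear on it.

Measured compounds:
compound 1, `Cc1ccc2[nH]c(=O)c(CN(Cc3ccc(OC(F)F)cc3)Cc3ccc(C(C)(C)C)cc3)cc2c1`, > 5000 nM
compound 2, `Cc1ccc2[nH]c(=O)c(CN(Cc3ccc(C(C)(C)C)cc3)[C@H](C)c3ccc(F)cc3)cc2c1`, > 5000 nM

In a toxicity assay on MDCK cells (Canis lupus familiaris) for cytotoxicity, read by crystal violet staining, with a stated time of 48 h (a lower number here means that less compound is tolerated, a higher number that more compound is tolerated), compound 1 gives > 5000 nM, which is a limit of the assay and not a number. Compound 2 gives > 5000 nM in this assay, likewise a limit. The step that the two limits leave unreadable from compound 1 to compound 2 is therefore not readable in size or direction, and the whole record for this assay consists of the limit of > 5000 nM in this assay, at which 2 of the 2 values shown sit.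

Compound 3, `Cc1ccc2[nH]c(=O)c(CN(Cc3ccc(C(C)(C)C)cc3)C(C)c3ccc(N(C)C)c(Cl)c3)cc2c1`, differs from compound 2 only at the amine nitrogen: 1-(3-chloro-4-(dimethylamino)phenyl)ethyl in place of 1-(4-fluorophenyl)ethyl on an amine nitrogen. Within the data shown here, the only measured step that touches this nitrogen is a step that the two limits leave unreadable from compound 1 to compound 2, and it gives no readable size, so no measured change of the group on this nitrogen has yet moved a compound off the limit. On that basis the step of a number no higher from compound 2 to compound 3 (the limit leaves the size open) is expected to be none beyond the scatter, with compound 3 staying at or near the same limit, though a reading below it cannot be ruled out from two limits alone. Compound 3 is therefore estimated at 5000 nM in this assay, within the range 1500 nM to 12000 nM.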

Compound 3, half-maximal cytotoxic concentration: 9800 nM
For compound 3 the middle estimate is 2.0-fold (0.29 log units) below the measured one; measured number inside the range.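

The steps to compound 3 from compound 1 and from compound 2 cannot be read, since each of those two compounds gives only a limit and not a number in this assay: the limit of > 5000 nM in this assay, at which 2 of the 3 values shown sit.

The compounds shown leave open whether changing the group on the amine nitrogen moves the tolerated concentration at all, and by how much.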